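The source may report more compounds than this note shows. Statements on the series, on what has been measured and on what is new or still open speak of the compounds shown alone.

Compound 1 `O=C(/C=C/c1coc2cc(O)ccc2c1=O)NCc1ccccc1` gives > 100000 nM in a functional assay on HeLa cells (Homo sapiens) for inhibition, read by MTT assay, with a stated time of 48 h (a higher number here means a weaker inhibitor, a lower number a stronger inhibitor), a limit of the assay rather than a number. Compound 2 `O=C(/C=C/c1coc2cc(O)ccc2c1=O)NCc1ccc(F)cc1` gives > 100000 nM in this assay, likewise a limit. Compound 3 `COc1ccc(NC(=O)/C=C/c2coc3cc(O)ccc3c2=O)cc1` gives > 100000 nM in this assay, again a limit.

Compound 3 thus stands at the limit, as do the other two: the limit of > 100000 nM in this assay, at which 3 of the 3 values shown sit. Compound 4 `Cc1ccccc1NC(=O)/C=C/c1coc2cc(O)ccc2c1=O` differs from compound 3 in one place: 2-methylphenyl in place of 4-methoxyphenyl on an amide-type nitrogen. Two measured steps also change the group on this nitrogen, a step that the two limits leave unreadable from compound 1 to compound 3 and a step that the two limits leave unreadable from compound 2 to compound 3, yet both lie between limits, so their size cannot be read. No readable step bears on the change to compound 4. The step is expected to be a step that the limit leaves unreadable from compound 3 to compound 4. Compound 4 is therefore estimated at 200000 nM, with a range from 60000 nM to 700000 nM.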

Compound 4, half-maximal inhibitory concentration: 8670 nM
Beside the measured number, compound 4's estimate is 23-fold (1.36 log units) above it; measured number outside the range, below it.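

The group on the amide-type nitrogen can now be seen to matter in this assay. Putting 2-methylphenyl there gives a large fall in the number against each earlier group (an at least 11-fold lower number from compound 3 to compound 4 (1.06 log units; beyond the scatter); an at least 11-fold lower number from compound 2 to compound 4 (1.06 log units; beyond the scatter); an at least 11-fold lower number from compound 1 to compound 4 (1.06 log units; beyond the scatter)). Compound 4 is the only one of the set that comes off the limit: (the limit of > 100000 nM in this assay, at which 3 of the 4 values shown sit). Going by these compounds, with a single compound off the limit, it stays open which feature of the 2-methylphenyl group counts. On these data alone, how an unsubstituted phenyl, or a longer chain ending in an amine, would read on this nitrogen also stays open.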